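The source may hold more compounds than are shown below. What is called first, only, known or untested is meant among the compounds shown, and "the series" means these compounds.

This short account concerns compounds tested in a functional assay on a cell-free system (plasma) with sterol O-acyltransferase, Soat (Rattus norvegicus) as the target; a lower number here means that less compound is needed, a higher number that more compound is needed for the effect. Two of them have been measured so far. Compound 1, `CSc1cc(C)nc(SC)c1NC(=O)N(Cc1ccccc1)Cc1cccc(-c2ccn(C)n2)c1`, gives < 1 mg/kg in this assay; that figure is a limit of the assay, not a measured number. Compound 2, `CSc1cc(C)nc(SC)c1NC(=O)N(Cc1cccc(-c2cnn(C)c2)c1)C1CCCCCC1`, gives > 0.1 mg/kg in this assay, and this too is a limit rather than a number. For the measured compounds named here, compound 2 thus stands at a boundary of what the assay reported, and the other value available is also a boundary (the limit of < 1 mg/kg in this assay, at which 1 of the 2 values shown sits, (the limit of > 0.1 mg/kg in this assay, at which 1 of the 2 values shown sits)), so no step between measured compounds can be stated, and no size of change has yet been seen.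

Compound 3, `CSc1cc(C)nc(SC)c1NC(=O)N(Cc1ccccc1)Cc1cccc(-c2cnn(C)c2)c1`, is not yet measured. It differs from compound 2 in one place: benzyl in place of cycloheptyl on an amide-type nitrogen. Both groups have the same number of atoms and carry neither donors nor acceptors; one seven-membered non-aromatic ring of carbon only gives way to one six-membered aromatic ring of carbon only.

Going by the values given here, with no measured step to lean on, the step expected here, a step that the limit leaves unreadable from compound 2 to compound 3, is taken as small and without clear direction, not beyond the usual scatter. Compound 3 is therefore expected to give 0.4 mg/kg in this assay, within an estimated range from 0.12 mg/kg to 1.5 mg/kg, with a real chance that only a limit is reported once more.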

Compound 3, dose for half-maximal effect: > 0.1 mg/kg
Compound 3 was reported as a limit; the forecaster's own chance of this, stated with the estimate: 45%; the middle value does not contradict the limit.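

For the compounds shown here, compound 3, like compound 1 and compound 2, is reported only as a limit in this assay, and no step to compound 3 from compound 1 or compound 2 can be read. Still open, going by these compounds, is the actual dose each compound needs, and whether swapping cycloheptyl for benzyl, or 1-methyl-1H-pyrazol-3-yl for 1-methyl-1H-pyrazol-4-yl, changes it at all.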